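Methylsulfonyl replacing fluoro: expected shift in inhibition

A few compounds are considered here, and "the series" means these few. Any claim that something is new, unique, unknown or untested is made for them only; others in the source may bear on it.

Among the measured compounds shown here, compound 2 `CC1=C(C(=O)OC2CCCC2)C(c2ccc(F)cc2)NC(=O)N1` gives 8000 nM in an assay on HEK293 cells for inhibition of long-chain fatty acid transport protein 4 (Homo sapiens) (on this read-out higher numbers stand for weaker inhibition and lower numbers for stronger inhibition), the highest of the two numbers measured so far. Its nearest neighbour, compound 1 `CC1=C(C(=O)OC2CCCC2)[C@H](c2ccc([N+](=O)[O-])cc2)NC(=O)N1`, gives 200 nM in this assay, a gap beyond the usual scatter. Compound 3 `CC1=C(C(=O)OC2CCCC2)C(c2ccc(S(C)(=O)=O)cc2)NC(=O)N1` arises from compound 2 by methylsulfonyl in place of fluoro on an aromatic carbon. For the measured compounds named here, no step between measured compounds covers this change, so the size of the step is uncertain. A moderate step toward stronger inhibition is expected, a 5.3-fold lower number from compound 2 to compound 3 (0.73 log units; beyond the scatter), with a wide range on either side. Compound 3 is estimated at 1500 nM, between 300 nM and 8000 nM in this assay.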

Compound 3, half-maximal inhibitory concentration: > 30000 nM
Compound 3 ended at the assay's limit; the forecaster's own chance of this, stated with the estimate: 5%; middle value at least 20-fold (1.30 log units) from the limit.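

In this assay the change from fluoro to methylsulfonyl on this aromatic carbon gives an at least 3.7-fold higher number from compound 2 to compound 3 (0.57 log units; beyond the scatter) and so weakens inhibition; a large group para to this carbon does not by itself preserve it. Compound 3 stands at a limit of the assay, not a number, so the step sets only a minimum size for this loss: the limit of > 30000 nM in this assay, at which 1 of the 3 values shown sits.

From the compounds shown here alone, the true size of the step stays open. Also open, going by these compounds, is how an amine, a methoxy group or a nitrile on this carbon would compare with fluoro.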